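The compounds below may be only part of what the source reports. "The series", "measured", "known", "first", "only" and "open" are said of these compounds alone.

Working notes on the series. In a functional assay on A549 cells (Homo sapiens) for antiproliferative activity, read by MTT assay, with a stated time of 72 h (on this read-out higher numbers stand for weaker inhibition and lower numbers for stronger inhibition), compound 1 `C=CC(=O)Nc1cccc(Oc2nc(Nc3cccc(OC)c3)nc3c2CSCC3)c1` gives 10100 nM and compound 3 `CCC/C=C/C(=O)Nc1cccc(Oc2nc(Nc3cccc(OC)c3)nc3c2CSCC3)c1` gives 11800 nM. These two sit together at the low end of the numbers in hand, with a 1.2-fold higher number from compound 1 to compound 3 (0.07 log units; within the scatter). Compound 2 `C/C=C/C(=O)Nc1cccc(Oc2nc(Nc3cccc(OC)c3)nc3c2CSCC3)c1` gives 21100 nM, and a 2.1-fold higher number from compound 1 to compound 2 (0.32 log units; beyond the scatter). The remaining measured step is a 1.8-fold lower number from compound 2 to compound 3 (0.25 log units; within the scatter).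

Compound 4 `C=CC(=O)Nc1cccc(Oc2nc(Nc3ccc(OC)nc3)nc3c2CSCC3)c1` keeps the vinyl on the carbonyl carbon of compound 1 and changes another place: 6-methoxypyridin-3-yl in place of 3-methoxyphenyl on a nitrogen on an aromatic ring. Going by the values given here, none of the measured steps touches this group, since all three alter only the group on the carbonyl carbon. They therefore serve only as a gauge of how far numbers have moved in this series, and that movement is small. Among the compounds with values here, no measured compound shows what this exchange does, so no step beyond the scatter is expected in this assay, and no direction can be assigned. The step expected on this basis is a 1.0-fold lower number from compound 1 to compound 4 (0.00 log units; within the scatter). For compound 4 the estimate is 10000 nM, with an expected range from 3500 nM to 30000 nM.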

Compound 4, half-maximal inhibitory concentration: 14600 nM
Compound 4: the middle estimate sits 1.5-fold (0.16 log units) below what was measured; measured number inside the range.
By their numbers in this assay, from the lowest: compounds 1, 3, 4 and 2 (each within the scatter of the next, the first and the last beyond it).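

In this assay, the exchange of 3-methoxyphenyl for 6-methoxypyridin-3-yl on the nitrogen gives a 1.4-fold higher number from compound 1 to compound 4 (0.16 log units; within the scatter). Going by these compounds alone, this is the first measured step outside the group on the carbonyl carbon, and it shows that this place accepts an aromatic ring with 1 hetero atom in place of a ring of carbon only, with no step beyond the scatter on this read-out. Nothing in hand bears on why the exchange leaves the read-out within the scatter.

Whether the same exchange behaves alike with the pent-1-en-1-yl or prop-1-en-1-yl group on the carbonyl carbon remains open, since it is shown only with the vinyl group. Also open, from the compounds shown here alone, is what an amine or a carboxylic acid in place of the methoxy group would do in this assay series.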